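Aryl swap on the piperazine of a T-type channel blocker

This account rests on a few compounds, and the source may have more. Where it says the series, first, only, none or still open, it means among the compounds named here.

For the measured compounds named here, compound 1 `CCCc1nc(-c2ccccc2)c(CNCCCN2CCN(c3cccc(F)c3)CC2)o1` is one of three compounds measured in an assay on HEK293 cells for inhibition of Voltage-dependent T-type calcium channel subunit alpha-1G (Homo sapiens), read by patch clamp; a lower number here means a stronger inhibitor, a higher number a weaker inhibitor. In this assay compound 1 gives 3030 nM, which places it second highest of the three numbers. Compound 2 `CCCc1nc(-c2ccccc2)c(CNCCN2CCN(c3ccc(F)cc3)CC2)o1` gives 7080 nM, and compound 3 `CCCc1nc(-c2ccccc2)c(CNCCN2CCN(c3ccc(C(F)(F)F)cc3)CC2)o1` gives 1300 nM. Going by the values given here, the only single change among the measured compounds is that from compound 2 to compound 3, where a 5.4-fold lower number from compound 2 to compound 3 (0.74 log units; beyond the scatter).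

Compound 4 `CCCc1nc(-c2ccccc2)c(CNCCCN2CCN(c3ccc(C)cc3)CC2)o1` has not been measured. It differs from compound 1 in one place: 4-methylphenyl in place of 3-fluorophenyl on an amine nitrogen in a ring. Among the compounds with values here, no measured step covers this exact exchange; the step from compound 2 to compound 3 also alters the group on the phenyl ring, on a shorter chain, and moved the number modestly downward. On that basis a small downward movement, perhaps not beyond the scatter, is expected, a 1.5-fold lower number from compound 1 to compound 4 (0.18 log units; within the scatter). Compound 4 is therefore estimated at 2000 nM, within a range from 700 nM to 6000 nM in this assay.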

Compound 4, half-maximal inhibitory concentration: 130000 nM
Compound 4: the middle estimate sits 65-fold (1.81 log units) below what was measured; the measured number lies above the stated range.
By their numbers in this assay, from the lowest: compound 3; then compound 1; then compound 2; then compound 4.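

In this assay, 4-methylphenyl in place of 3-fluorophenyl on an amine nitrogen in a ring gives a 43-fold higher number from compound 1 to compound 4 (1.63 log units; beyond the scatter), so this place on the longer chain tolerates far less exchange than the modest step on the shorter chain, a 5.4-fold lower number from compound 2 to compound 3 (0.74 log units; beyond the scatter), had suggested. The two groups match in heavy-atom count, and both have no hydrogen-bond donors or acceptors and no net charge, so these counts do not separate a compound near the others from one far weaker. Nothing measured here accounts for the size of this step.

The step changes both the substituent and its numbered place on the phenyl ring, and the compounds shown do not separate the two. They also leave open how an unsubstituted phenyl or a chloro-substituted phenyl would stand on this chain.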